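From Methyl to Trifluoromethyl in Compound 2

The source may hold more compounds than are shown below. What is called first, only, known or untested is meant among the compounds shown, and "the series" means these compounds.

Among the measured compounds shown here, compound 2 `Cc1ccc(N2CCN(Cc3csc(N)c3C(=O)c3ccc(Cl)cc3)CC2)cc1` gives 1 nM in an assay on CHO cells for displacement of a labelled ligand from adenosine receptor A1 (Homo sapiens); on this read-out lower numbers stand for tighter binding and higher numbers for weaker binding; compound 1 `CN1CCN(Cc2csc(N)c2C(=O)c2ccc(Cl)cc2)CC1` gives 1.2 nM in this assay, and the step of a 1.2-fold lower number from compound 1 to compound 2 (0.08 log units; within the scatter) puts compound 2 at one end of the two numbers so far, within the scatter of compound 1. Compound 3 `Nc1scc(CN2CCN(c3ccc(C(F)(F)F)cc3)CC2)c1C(=O)c1ccc(Cl)cc1` carries trifluoromethyl in place of methyl on an aromatic carbon. For the measured compounds named here, the one measured step changed a different part of the molecule, so nothing measured bears directly on this change. The step in this assay is expected to be a 1.5-fold higher number from compound 2 to compound 3 (0.18 log units; within the scatter), not beyond the scatter. The estimate for compound 3 is 1.5 nM, with a range from 0.5 nM to 4.5 nM.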

Compound 3, dissociation constant: 1 nM
Compound 3: middle estimate off by 1.5-fold (0.18 log units), on the high side; measured number inside the range.
By their numbers in this assay, from the lowest: compounds 2, 3 and 1 (each within the scatter of the next).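

Trifluoromethyl in place of methyl on this aromatic carbon gives no change at the digits printed from compound 2 to compound 3 (within the scatter) in this assay, so the three fluorine atoms leave binding unchanged at this site, para to a large group. The step of a 1.2-fold lower number from compound 1 to compound 3 (0.08 log units; within the scatter) shows that the 4-(trifluoromethyl)phenyl group on the ring amine nitrogen also matches the small methyl there. Two different substituents on this aromatic carbon now give the same result.

Going by these compounds, whether an amine, a carboxylic acid or a longer chain on this carbon would also keep binding this tight remains open. Nothing shown gives a reason for this flat result.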